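A few compounds are considered here, and "the series" means these few. Any claim that something is new, unique, unknown or untested is made for them only; others in the source may bear on it.

In a functional assay on KB cells (Homo sapiens) for inhibition (on this read-out lower numbers stand for stronger inhibition and higher numbers for weaker inhibition), two compounds on one shared core have been measured so far. Compound 1 (`COc1ccc(Cn2c(N)nc3cc(Cl)c(Cl)cc32)cc1`) gives 45000 nM and compound 2 (`Cc1ccc(Cn2c(N)nc3cc(Cl)c(Cl)cc32)cc1`) gives 50000 nM on this read-out, so compound 2 stands level with compound 1 within the scatter. Among the measured compounds shown here, the one measured step, a 1.1-fold higher number from compound 1 to compound 2 (0.05 log units; within the scatter) for methyl in place of methoxy on an aromatic carbon, stays within that scatter. Compound 3 (`CC(C)(C)c1ccc(Cn2c(N)nc3cc(Cl)c(Cl)cc32)cc1`) carries tert-butyl in place of methyl on an aromatic carbon para to a large group. For the measured compounds named here, the measured step bears only loosely on this change: it exchanged other groups, and no measured compound carries tert-butyl. In this assay no step beyond the scatter is therefore expected, and the range is kept wide. The estimate amounts to a 1.3-fold lower number from compound 2 to compound 3 (0.10 log units; within the scatter) at its middle. For compound 3 the expected value is 40000 nM within an estimated range from 15000 nM to 100000 nM overall.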

Compound 3, half-maximal inhibitory concentration: 50000 nM
Compound 3: the middle estimate sits 1.3-fold (0.10 log units) below what was measured; low and high end bracket the measured number.
By their numbers in this assay, from the lowest: compounds 1, 2 and 3 (each within the scatter of the next).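

In this assay the exchange of methyl for tert-butyl (no change at the digits printed from compound 2 to compound 3 (within the scatter)) and the exchange of methoxy for tert-butyl (a 1.1-fold higher number from compound 1 to compound 3 (0.05 log units; within the scatter)) both stay within the scatter. The earlier pair compared only methoxy and methyl, whereas this result shows that on this aromatic carbon, para to a large group, tert-butyl with its 4 heavy atoms also stands level with methyl with its 1 heavy atom, so none of the three groups separates from the others here. No measurement shown offers an explanation for this level reading.

The compounds shown leave open whether an amine, a carboxylic acid or a hydroxyl group at this place would move the number beyond the scatter. They also leave open whether any change elsewhere on the shared core would do so.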